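The source may report more compounds than this note shows. Statements on the series, on what has been measured and on what is new or still open speak of the compounds shown alone.

Of the compounds shown here, two that share a core have so far been tested in a functional assay on HCT-116 cells (Homo sapiens) for antiproliferative activity, read by sulforhodamine B assay, with a stated time of 48 h; a higher number here means a weaker inhibitor of growth, a lower number a stronger inhibitor of growth. Compound 1 `O=C(/C=C/c1cccc(S(=O)(=O)c2ccc3ccccc3n2)c1)NO` gives 80 nM. Compound 2 `COc1ccc2nc(S(=O)(=O)c3cccc(/C=C/C(=O)NO)c3)ccc2c1`, which carries a methoxy in place of hydrogen on an aromatic carbon, gives 240 nM, the higher of the two numbers, so compound 2 stands as the weaker growth inhibitor of this pair. Going by the values given here, that single comparison, a 3.0-fold higher number from compound 1 to compound 2 (0.48 log units; beyond the scatter), is the only measured step available. Compound 3 `O=C(/C=C/c1cccc(S(=O)(=O)c2ccc3cc(Cl)ccc3n2)c1)NO` has not yet been measured; it differs from compound 2 by chloro in place of methoxy on an aromatic carbon. Among the compounds with values here, no measured step involves a chloro group, so the only guide is that the methoxy now leaving cost a modest amount. Going by these compounds, its removal points back toward compound 1, while the entering chloro remains untested, so a step of a 2.0-fold lower number from compound 2 to compound 3 (0.30 log units; within the scatter) is expected. Compound 3 is therefore estimated at 120 nM, within a range from 50 nM to 350 nM.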

Compound 3, concentration for 50% growth inhibition: 920 nM
Compound 3: the middle estimate sits 7.7-fold (0.88 log units) below what was measured, outside the stated range (above it).
By their numbers in this assay, from the lowest: compound 1; then compound 2; then compound 3.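

In this assay the swap of methoxy for chloro on this ring carbon does not move the number back toward compound 1 but further away, with a 3.8-fold higher number from compound 2 to compound 3 (0.58 log units; beyond the scatter). Set against the unsubstituted parent, the chloro group brings a 12-fold higher number from compound 1 to compound 3 (1.06 log units; beyond the scatter), a larger cost than the methoxy group's a 3.0-fold higher number from compound 1 to compound 2 (0.48 log units; beyond the scatter), so both groups give weaker growth inhibition here than hydrogen does. Chloro has fewer heavy atoms than methoxy yet gives the weaker compound, so among these three compounds the order does not follow the heavy-atom count of the group.

The data offer no measured reason for this order. Going by these compounds, whether any group at this carbon can match hydrogen remains open, for instance an amine, a carboxylic acid or a longer chain such as ethoxy.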